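A few compounds are considered here, and "the series" means these few. Any claim that something is new, unique, unknown or untested is made for them only; others in the source may bear on it.

Compound 1 `COc1cc(/C=C/C(=O)OCCCN(C)[C@H]2CC[C@H](OC(=O)c3cc(OC)c(OC)c(OC)c3)CC2)cc(OC)c1OC`: <= 2 h (limit)
Compound 2 `COc1cc(/C=C/C(=O)OCCCCN(C)[C@H]2CC[C@@H](OC(=O)c3cc(OC)c(OC)c(OC)c3)CC2)cc(OC)c1OC`: >= 4 h (limit)

In an ADME assay on a cell-free system (plasma, Homo sapiens) for metabolic stability, read by LC-MS (a lower number here means that the compound disappears faster, a higher number that the compound lasts longer), compound 2 stands at >= 4 h, which is a limit and not a number. Compound 3 `COc1cc(/C=C/C(=O)OCCCCN(C)[C@H]2CC[C@H](OC(=O)c3cc(OC)c(OC)c(OC)c3)CC2)cc(OC)c1OC` has the same atoms and bonds as compound 2 and differs only in configuration as drawn: the two compounds have the same atoms and bonds and differ only in configuration as drawn: 2 of 3 stereo elements differ; a stereocentre at a saturated ring carbon is drawn s in compound 2 and r in compound 3; a stereocentre at a saturated ring carbon is drawn s in compound 2 and r in compound 3. Going by the values given here, no measured step covers a change of this kind, so the estimate rests only on the two limits. A modest shortening of the half-life is expected, with an estimated at least 1.3-fold lower number from compound 2 to compound 3 (0.12 log units; that floor lies within the scatter). Compound 3 is estimated at 3 h, with an expected range of 1 h to 6 h.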

Compound 3, half-life: 2 h
Beside the measured number, compound 3's estimate is 1.5-fold (0.18 log units) above it; measured number inside the range.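

With atoms and bonds unchanged, this assay gives an at least 2.0-fold lower number from compound 2 to compound 3 (0.30 log units; that floor lies within the scatter). Compound 2 enters this step as a limit, >= 4 h, so only a floor on the size of the step can be read. Compound 1 and compound 2 differ in more than one place, whereas this step can be tied to configuration alone because of one fact: the fact that compounds 2 and 3 differ only in the configuration as drawn.

From the compounds shown here alone, whether the same change of configuration matters with a longer chain, or with an amide in place of either ester, remains open. Going by these compounds, the exact half-life of compound 2 also remains open.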